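Methyl added to the phenyl ring of compound 1

This account rests on a few compounds, and the source may have more. Where it says the series, first, only, none or still open, it means among the compounds named here.

Compound 1 `C=CC(=O)Nc1ccccc1Nc1ccc2c(C(=O)c3cc(OC)cc(OC)c3)c[nH]c2n1` holds the lowest number of the two compounds measured in a functional assay on Hep 3B2 cells (Homo sapiens) for antiproliferative activity, with a stated time of 72 h; a lower number here means a stronger inhibitor, a higher number a weaker inhibitor: compound 1 gives 140 nM. Among the measured compounds shown here, its nearest neighbour is compound 2 `CC#CC(=O)Nc1ccccc1Nc1ccc2c(C(=O)c3cc(OC)cc(OC)c3)c[nH]c2n1`, which in this assay gives 602 nM; the single step recorded, a 4.3-fold higher number from compound 1 to compound 2 (0.63 log units; beyond the scatter), concerns only the group on the carbonyl carbon of the amide.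

Compound 3 `C=CC(=O)Nc1cccc(C)c1Nc1ccc2c(C(=O)c3cc(OC)cc(OC)c3)c[nH]c2n1` differs from compound 1 by methyl in place of hydrogen on an aromatic carbon. For the measured compounds named here, no measured step touches this part of the shared core; the step from compound 1 to compound 2 alters the amide end and says nothing about a methyl on the aromatic ring. Going by the values given here, with no bearing step available, the expectation for this assay is a change that does not exceed the scatter, in either direction, giving an expected step of a 1.1-fold higher number from compound 1 to compound 3 (0.03 log units; within the scatter). Compound 3 is therefore estimated at 150 nM, with a range from 50 nM to 450 nM.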

Compound 3, half-maximal inhibitory concentration: 438 nM
Estimate against measurement, compound 3: 2.9-fold (0.47 log units) below, and the stated range covers the measured number.
By their numbers in this assay, from the lowest: compound 1; then compounds 3 and 2 (each within the scatter of the next).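

At this aromatic carbon, ortho to a large group and meta to the (vinylcarbonyl)amino group, a single added methyl is enough to weaken this assay: a 3.1-fold higher number from compound 1 to compound 3 (0.50 log units; beyond the scatter). Among the compounds shown here, until now the only recorded change lay at the amide end, so this is the first sign that the six-membered aromatic ring carrying the amide also affects the number, and that hydrogen is preferred over methyl at this carbon. No measurement at hand gives a reason for this step.

From the compounds shown here alone, it remains open whether the loss belongs to methyl alone or also appears with a chlorine atom or a methoxy group on the same carbon, and whether methyl on another carbon of this ring gives a step of similar size. Also open, going by these compounds, is whether the step holds with prop-1-yn-1-yl on the amide carbonyl, as in compound 2.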